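Amide cap variation on the shared core

This account rests on a few compounds, and the source may have more. Where it says the series, first, only, none or still open, it means among the compounds named here.

Measured so far in a functional assay on HepG2 cells (Homo sapiens) for cytotoxicity, read by MTT assay, with a stated time of 72 h; on this read-out lower numbers stand for stronger inhibition and higher numbers for weaker inhibition:
compound 1 `CN1[C@@H]2c3[nH]c4ccccc4c3C[C@H]1[C@H](C#N)N1[C@@H](CNC(=O)c3cccc4c3CCCC4)c3[nH]c4ccccc4c3C[C@@H]21`: 540 nM
compound 2 `CN1[C@@H]2c3[nH]c4ccccc4c3C[C@H]1[C@H](C#N)N1[C@@H](CNC(=O)c3cc4ccccc4[nH]3)c3[nH]c4ccccc4c3C[C@@H]21`: 440 nM

Among the measured compounds shown here, compound 1 stands alongside compound 2, the only other measured member, and nothing beyond the scatter separates the two: the one measured step, a 1.2-fold lower number from compound 1 to compound 2 (0.09 log units; within the scatter), swaps the group on the carbonyl carbon of the amide and leaves the number essentially where it was.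

Compound 3 `COc1ccc(/C=C/C(=O)NC[C@H]2c3[nH]c4ccccc4c3C[C@H]3[C@H]4c5[nH]c6ccccc6c5C[C@@H]([C@H](C#N)N23)N4C)cc1` is not yet measured. Against compound 1 the change is 2-(4-methoxyphenyl)ethenyl in place of 1,2,3,4-tetrahydronaphthalen-5-yl on a carbonyl carbon. It is the same kind of change as the measured one, a different group on the same carbonyl carbon while the rest of compound 1 is kept. For the measured compounds named here, only the step from compound 1 to compound 2 bears on it, and that step was within the scatter. On this basis no step beyond the scatter is expected for compound 3, so the estimated step is a 1.0-fold higher number from compound 1 to compound 3 (0.01 log units; within the scatter). Going by the values given here, the expected value for compound 3 in this assay is 550 nM, with a range from 250 nM to 1300 nM, the range kept wide since only one neighbouring step is known.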

Compound 3, half-maximal inhibitory concentration: 2140 nM
The estimate for compound 3 lay 3.9-fold (0.59 log units) below the measured number, and the stated range ends below it.
By their numbers in this assay, from the lowest: compounds 2 and 1 (each within the scatter of the next); then compound 3.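

At the carbonyl carbon of the amide, the group can move the number in this assay beyond the scatter, which the earlier pair did not show: with 2-(4-methoxyphenyl)ethenyl the series gives a 4.0-fold higher number from compound 1 to compound 3 (0.60 log units; beyond the scatter) and also a 4.9-fold higher number from compound 2 to compound 3 (0.69 log units; beyond the scatter). The heavy-atom count does not separate compound 1 from compound 3, since the leaving 1,2,3,4-tetrahydronaphthalen-5-yl and the entering 2-(4-methoxyphenyl)ethenyl both have 10 heavy atoms, while the entering group differs in having 1 double bond outside aromatic rings, 1 hydrogen-bond acceptor and one ring fewer. No measurement is available to explain the higher number of compound 3.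

The compounds shown do not separate the contributions of the double bond and the methoxy group, and a 2-phenylethenyl cap or a saturated 2-(4-methoxyphenyl)ethyl cap on the shared core would address that directly. On these data alone, how a cap carrying an amine or a carboxylic acid would read in this assay also remains open.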